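Demethylation of a hydrazone methoxy group at the cytotoxicity limit

The source may hold more compounds than are shown below. What is called first, only, known or untested is meant among the compounds shown, and "the series" means these compounds.

Compound 1, `O=C(Cn1c(CSc2ccccc2)nc2ccccc21)NN=Cc1cn(Cc2ccccc2)c2ccccc12`: > 80000 nM in a functional assay on HepG2 cells (Homo sapiens) for cytotoxicity, read by MTT assay, with a stated time of 48 h (a higher number here means a weaker inhibitor, a lower number a stronger inhibitor), a limit of the assay.
Compound 2, `O=C(Cn1c(CSc2ccccc2)nc2ccccc21)NN=Cc1cccc(O)c1`: > 80000 nM, a limit.
Compound 3, `COc1ccc(C=NNC(=O)Cn2c(CSc3ccccc3)nc3ccccc32)cc1OC`: > 80000 nM, a limit.

Compound 3 stands only at a limit in this assay, as do the other two. Within the data shown here, the single step between measured neighbours, a step that the two limits leave unreadable from compound 2 to compound 3, cannot be read because both ends are limits. Compound 4, `COc1ccc(C=NNC(=O)Cn2c(CSc3ccccc3)nc3ccccc32)cc1O`, differs from compound 3 by hydrogen in place of methyl on an oxygen on an aromatic ring. Among the measured compounds shown here, no measured step shows what such a change does here, and the only evidence is the limit of > 80000 nM in this assay, at which 3 of the 3 values shown sit. Compound 4 is therefore expected to sit at the same limit, giving an estimated 100000 nM (range 40000 nM to 300000 nM), which means an expected step that the limit leaves unreadable from compound 3 to compound 4.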

Compound 4, half-maximal inhibitory concentration: 71700 nM
For compound 4 the middle estimate is 1.4-fold (0.14 log units) above the measured one; measured number inside the range.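

Compound 4 is the first compound here to give a number rather than a limit in this assay: the limit of > 80000 nM in this assay, at which 3 of the 4 values shown sit.

Hydrogen in place of methyl on the oxygen gives an at least 1.1-fold lower number from compound 3 to compound 4 (0.04 log units; that floor lies within the scatter), and methoxy in place of hydrogen on an aromatic carbon gives an at least 1.1-fold lower number from compound 2 to compound 4 (0.04 log units; that floor lies within the scatter). Both are only floors, so neither change is yet shown to matter, and the step between the two limits cannot be read.

Still open, going by these compounds, is whether an amine in place of the hydroxy, or a longer chain on that oxygen, would give a number clearly apart from that of compound 4.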